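A few compounds are considered here, and "the series" means these few. Any claim that something is new, unique, unknown or untested is made for them only; others in the source may bear on it.

Measured in a functional assay on ileum (Cavia porcellus) for antagonist activity; on this read-out higher numbers stand for weaker inhibition and lower numbers for stronger inhibition:
- compound 1 `CCCc1c(OCC(O)COc2ccc3c(O)c([N+](=O)[O-])c(=O)oc3c2C)ccc(C(C)=O)c1O`: 25 nM
- compound 2 `CCCc1c(O)c(C(C)=O)cc([N+](=O)[O-])c1OCC(O)COc1ccc2c(O)c([N+](=O)[O-])c(=O)oc2c1C`: 1600 nM

Compound 1 holds the lower of the two numbers, so it is the stronger inhibitor of this pair. Compound 3 `CCCc1c(OCC(O)COc2ccc3c(O)c([N+](=O)[O-])c(=O)oc3c2CCC)ccc(C(C)=O)c1O` alters compound 1 in one place: ethyl in place of hydrogen on a saturated chain carbon bound to an aromatic carbon. In other words, methyl becomes propyl. Within the data shown here, the only measured step is a 64-fold higher number from compound 1 to compound 2 (1.81 log units; beyond the scatter), which is large, but it comes from nitro in place of hydrogen on an aromatic carbon, a different change, so it gives little guidance here. With no measured evidence for a direction, no shift beyond the scatter is expected in this assay. The expected step is a 1.2-fold higher number from compound 1 to compound 3 (0.08 log units; within the scatter). The estimated value for compound 3 is 30 nM, within a range of 8 nM to 120 nM.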

Compound 3, half-maximal inhibitory concentration: 200 nM
The estimate for compound 3 lay 6.7-fold (0.82 log units) below the measured number; measured number outside the range, above it.
By their numbers in this assay, from the lowest: compound 1; then compound 3; then compound 2.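

In this assay the change from methyl to propyl gives an 8.0-fold higher number from compound 1 to compound 3 (0.90 log units; beyond the scatter), so the group on this saturated chain carbon bound to an aromatic carbon does affect inhibition. Here the longer chain goes with weaker inhibition, something the earlier nitro step could not show about this place. Nothing measured here accounts for the shift.

As far as these compounds go, with only methyl and propyl to compare at this place, the trend with chain length remains unknown. Also open, from the compounds shown here alone, is how butyl, or a chain carrying an amine, would compare with compound 1 .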